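The compounds below may be only part of what the source reports. "The series", "measured", "known", "first", "only" and "open" are said of these compounds alone.

Measured in a physicochemical assay for solubility, read by HPLC, using the shake flask method, measured as kinetic solubility, with a stated time of 20 h, at pH 6.5, tested at 200 uM; a lower number here means a less soluble compound, a higher number a more soluble compound:
Compound 1 `CS(=O)(=O)c1cccc(-c2ccc3nccc(N4CCNCC4)c3n2)c1`: 165000 nM
Compound 2 `NS(=O)(=O)c1ccc(-c2ccc3nccc(-c4ccncc4)c3n2)cc1`: 25000 nM

Of these two compounds, compound 2 has the lower number, at 25000 nM. The number for compound 1 is higher by a margin beyond the usual scatter of repeated measurements, but the two compounds differ in more than one place, so that gap says little about any single change.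

Compound 3 `O=S(=O)(NCCO)c1ccc(-c2ccc3nccc(-c4ccncc4)c3n2)cc1` is compound 2 with 2-hydroxyethyl in place of hydrogen on a sulfonamide nitrogen. For the measured compounds named here, no measured pair isolates this change, so the expectation in this assay rests only on compound 2 at 25000 nM and on the structural difference. A slight upward move, not clearly beyond the scatter, is expected, and the estimate is a 1.4-fold higher number from compound 2 to compound 3 (0.15 log units; within the scatter). Compound 3 is estimated at 35000 nM, with an expected range from 12000 nM to 100000 nM.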

Compound 3, solubility: 50000 nM
Beside the measured number, compound 3's estimate is 1.4-fold (0.15 log units) below it; the measured number falls inside the stated range.
By their numbers in this assay, from the lowest: compounds 2 and 3 (each within the scatter of the next); then compound 1.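

In this assay, the sulfonamide nitrogen, whose other neighbour is the sulfonyl sulfur, now has its first direct reading: 2-hydroxyethyl in place of hydrogen gives a 2.0-fold higher number from compound 2 to compound 3 (0.30 log units; within the scatter) on an otherwise unchanged structure. Unlike the gap between compound 1 and compound 2, which spans more than one difference, this step isolates a single change, and it shows that this position can carry 2-hydroxyethyl with no shift that stands clear of the scatter. No measured information is available to explain this result.

This single pair cannot show how a simple methyl group, a longer chain ending in hydroxyl, or a chain ending in an amine or a carboxylic acid would read at this nitrogen. Nor does it show whether the same change would read alike on a different core.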